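Swapping the aniline on a shared urea core

The source may report more compounds than this note shows. Statements on the series, on what has been measured and on what is new or still open speak of the compounds shown alone.

Compound 1 `Cc1ccc(Nc2cc(NC(=O)Nc3c(Cl)cccc3Cl)ncn2)cc1F`: 33.5%
Compound 2 `COc1ccc(C(F)(F)F)cc1Nc1cc(NC(=O)Nc2c(Cl)cccc2Cl)ncn1`: 33%
Compound 3 `COc1cc(NC(=O)Nc2cc(Nc3ccc(OC)c(I)c3)ncn2)cc(OC)c1`: 46.5%

Of the compounds shown here, three have been measured in a functional assay on NCI-H520 cells (Homo sapiens) for inhibition, read by MTT assay, with a stated time of 48 h, tested at 10 uM; a higher number here means more inhibition at the concentration tested (going by the name of the read-out), a lower number less inhibition. Compound 3 gives the highest of the three numbers; its gap to compound 1, the nearest, lies beyond the usual scatter, and its gap to compound 2, the furthest, lies beyond the scatter as well. Compound 3 therefore shows the highest number of the measured set in this assay.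

Compound 4 `CCc1ccc(Nc2cc(NC(=O)Nc3cc(OC)cc(OC)c3)ncn2)cc1` has not yet been measured. It keeps the core of compound 3 and differs in one place: 4-ethylphenyl in place of 3-iodo-4-methoxyphenyl on a nitrogen on an aromatic ring. Among the compounds with values here, no measured pair shows this particular swap, so nothing in the data tells how large its effect is. The change removes the iodine and the methoxy group and brings in an ethyl group instead, on the nitrogen attached to the aromatic ring.

Within the data shown here, with no direct precedent, the step from compound 3 to compound 4 is expected to be small, tending downward, about a number 8.5 percentage points lower from compound 3 to compound 4 (within the scatter). Compound 4 is estimated to reach 38% in this assay, within a range from 20% to 55%.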

Compound 4, a percentage reported as inhibition, at one concentration (the size of the read-out at that concentration, not a potency): 23.5%
Compound 4: the middle estimate sits 14.5 percentage points above what was measured; measured number inside the range.
By their numbers in this assay, from the lowest: compounds 4, 2 and 1 (each within the scatter of the next); then compound 3.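

Within this assay the swap of 3-iodo-4-methoxyphenyl for 4-ethylphenyl on this nitrogen gives a number 23 percentage points lower from compound 3 to compound 4 (beyond the scatter) and is the first single change in the set whose size can be read. It shows that the number responds to what sits at this position, even though the two groups are close in heavy-atom count and each carries a single carbon-only aromatic ring. The iodine and the methoxy group leave together as the ethyl group enters, so the step cannot be assigned to any one of them, and no independent measurement bears on it.

Open, on these data alone, is whether a phenyl ring carrying only the methoxy group or only the iodine would keep the higher number. Also open, as far as these compounds go, is how an amine or a carboxylic acid on this ring would read.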